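Amide Nitrogen Substituent Swap on Two Pyridyl-Ethenyl Cores

The source may hold more compounds than are shown below. What is called first, only, known or untested is meant among the compounds shown, and "the series" means these compounds.

Measured compounds:
Compound 1 `O=C(NCc1ccc(F)cc1)c1cc(Oc2ccc(/C=C/c3ccccn3)cc2)ccn1` — 45100 nM
Compound 2 `CC(C)NC(=O)c1cc(Oc2ccc(/C=C/c3ccccn3)cc2)ccn1` — > 100000 nM
Compound 3 `O=C(NCc1ccc(F)cc1)c1cc(Oc2ccc(/C=C/c3ccncc3)cc2)ccn1` — 37200 nM

The series was examined in a functional assay on HepG2 cells (Homo sapiens) for antiproliferative activity, read by CCK-8 assay, with a stated time of 48 h; a higher number here means a weaker inhibitor, a lower number a stronger inhibitor. Compound 1 `O=C(NCc1ccc(F)cc1)c1cc(Oc2ccc(/C=C/c3ccccn3)cc2)ccn1` gives 45100 nM in this assay. Compound 2 `CC(C)NC(=O)c1cc(Oc2ccc(/C=C/c3ccccn3)cc2)ccn1` reaches only a limit of the assay in this assay, > 100000 nM, and the result is recorded as such (the limit of > 100000 nM in this assay, at which 1 of the 3 values shown sits). The change from compound 1 to compound 2 is isopropyl in place of 4-fluorobenzyl on an amide-type nitrogen, and it produced an at least 2.2-fold higher number from compound 1 to compound 2 (0.34 log units; beyond the scatter).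

Compound 3 `O=C(NCc1ccc(F)cc1)c1cc(Oc2ccc(/C=C/c3ccncc3)cc2)ccn1` differs from compound 1 in its core, as pyridin-4-yl in place of pyridin-2-yl on a double-bonded chain carbon bound to a double-bonded chain carbon; in this assay compound 3 gives 37200 nM, and the step of a 1.2-fold lower number from compound 1 to compound 3 (0.08 log units; within the scatter) shows the two cores behaving alike.

Compound 4 `CC(C)NC(=O)c1cc(Oc2ccc(/C=C/c3ccncc3)cc2)ccn1` has not yet been measured. Its difference from compound 3 is isopropyl in place of 4-fluorobenzyl on an amide-type nitrogen, the same change already seen between compound 1 and compound 2, at the same place. Because the earlier step was an at least 2.2-fold higher number from compound 1 to compound 2 (0.34 log units; beyond the scatter), a weakening of at least similar size is expected here, so compound 4 is estimated at 100000 nM, with a likely range from 55000 nM to 200000 nM, and most probably a limit rather than a number. The expected step is a 2.7-fold higher number from compound 3 to compound 4 (0.43 log units; beyond the scatter).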

Compound 4, half-maximal inhibitory concentration: 33700 nM
Compound 4: the middle estimate sits 3.0-fold (0.47 log units) above what was measured, outside the stated range (below it).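

In this assay, isopropyl in place of 4-fluorobenzyl on an amide-type nitrogen gave a 1.1-fold lower number from compound 3 to compound 4 (0.04 log units; within the scatter), so the weakening seen on the core of compound 1 did not reappear on the core of compound 3, and the two steps compare as follows: the same change on two cores in this assay, an at least 2.2-fold higher number (0.34 log units; beyond the scatter) from compound 1 to compound 2 and a 1.1-fold lower number (0.04 log units; within the scatter) from compound 3 to compound 4; the limit leaves it open whether they differ. Read the other way, pyridin-4-yl in place of pyridin-2-yl gave an at least 2.9-fold lower number from compound 2 to compound 4 (0.47 log units; beyond the scatter) with isopropyl on the amide, and this sits beside the step with 4-fluorobenzyl: the same change on two cores in this assay, a 1.2-fold lower number (0.08 log units; within the scatter) from compound 1 to compound 3 and an at least 2.9-fold lower number (0.47 log units; beyond the scatter) from compound 2 to compound 4; the limit leaves it open whether they differ. Compound 2 gives > 100000 nM, which is a limit of the assay and not a number, so the series does not show how much the outcome of the amide change depends on the core, only that the weakening was not carried over to the core of compound 3.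

The compounds shown leave open how a longer chain such as n-butyl, or a benzyl without fluorine, would read on the amide-type nitrogen of either core. They also leave open whether a chain bearing an amine would behave alike on both cores.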